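Nitro in Place of Chloro: Expected Inhibition for Compound 3

The source may hold more compounds than are shown below. What is called first, only, known or untested is meant among the compounds shown, and "the series" means these compounds.

Compound 1, `O=c1oc(-c2ccc([N+](=O)[O-])cc2Cl)ns1`: 54.6%
Compound 2, `O=c1oc(-c2ccccc2Cl)ns1`: 20.6%

In an ADME assay on L02 cells (Homo sapiens) for inhibition, read by MTT assay, with a stated time of 48 h, tested at 100 uM (a higher number here means more inhibition at the concentration tested (going by the name of the read-out), a lower number less inhibition), compound 2 gives 20.6%, the lowest of the two numbers shown; the nearest is compound 1 at 54.6%, higher beyond the scatter. Compound 3, `O=c1oc(-c2ccccc2[N+](=O)[O-])ns1`, differs from compound 2 by nitro in place of chloro on an aromatic carbon. Among the measured compounds shown here, the one measured step that bears on this change is a number 34 percentage points lower from compound 1 to compound 2 (beyond the scatter), where hydrogen in place of nitro lowered inhibition. Compound 3 likewise takes on a nitro, here in exchange for chloro. The step is therefore expected to be a number 19.4 percentage points higher from compound 2 to compound 3 (beyond the scatter). Compound 3 is estimated to give 40%, with a range from 20% to 62%.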

Compound 3, a percentage reported as inhibition, at one concentration (the size of the read-out at that concentration, not a potency): 32.4%
Compound 3: the middle estimate sits 7.6 percentage points above what was measured; the measured number falls inside the stated range.
By their numbers in this assay, from the lowest: compound 2; then compound 3; then compound 1.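

In this assay nitro in place of chloro on this aromatic carbon gives a number 11.8 percentage points higher from compound 2 to compound 3 (beyond the scatter) as a modest step. The earlier pair followed only a nitro at another place on the ring, whereas this result shows that the chloro of compound 2 can be exchanged here without a loss of inhibition. Nothing available explains this step.

From the compounds shown here alone, whether an amine or a carboxylic acid on this carbon would raise or lower the number remains open. So does the effect of a longer chain there.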